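A few compounds are considered here, and "the series" means these few. Any claim that something is new, unique, unknown or untested is made for them only; others in the source may bear on it.

In a functional assay on MDA-MB-231 cells (Homo sapiens) for antiproliferative activity, with a stated time of 72 h (a higher number here means that more compound is needed for the effect, a lower number that less compound is needed), compound 1 `O=C(O)c1ccc(N(Cc2ccc(C3CCCCC3)cc2)C(=O)[C@H]2CCN2S(=O)(=O)c2c(F)c(F)c(F)c(F)c2F)c(F)c1` gives > 10000 nM, which is a limit of the assay and not a number. Compound 2 `O=C(NO)c1ccc(N(Cc2ccc(C3CCCCC3)cn2)C(=O)[C@H]2CCN2S(=O)(=O)c2c(F)c(F)c(F)c(F)c2F)cc1O` is recorded as "not determined" (no result reported). Compound 3 `NC(=O)c1ccc(N(Cc2ccc(C3CCCCC3)cn2)C(=O)[C@H]2CCN2S(=O)(=O)c2c(F)c(F)c(F)c(F)c2F)c(F)c1` is recorded as "not determined" (no result reported), so it has no number of its own to stand on. The next structure is compound 4 `O=C([C@H]1CCN1S(=O)(=O)c1c(F)c(F)c(F)c(F)c1F)N(Cc1ccc(C2CCCCC2)cn1)c1ccc2c(=O)[nH]ccc2c1`. The change is a group of 11 heavy atoms (9 carbon, 1 nitrogen, 1 oxygen; one six-membered aromatic ring of carbon only, one six-membered aromatic ring with 1 hetero atom) in place of a group of 10 heavy atoms (7 carbon, 1 nitrogen, 1 oxygen, 1 fluorine; one six-membered aromatic ring of carbon only), on an amide-type nitrogen. Among the compounds with values here, no measured step exists to scale this change. Only a modest shift in this assay is expected, towards less compound needed. Compound 1 at > 10000 nM, again a limit, is the sole anchor, so a result not far from that limit is expected. For compound 4 the estimate is 5000 nM, with an expected range of 1500 nM to 10000 nM.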

Compound 4, half-maximal effective concentration: 1200 nM
For compound 4 the middle estimate is 4.2-fold (0.62 log units) above the measured one; measured number below the stated range.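

No step can be read between compound 3 and compound 4: compound 3 has no number in this assay, while compound 4 gives 1200 nM. Still open, going by these compounds, is how much of that value belongs to the group entering on the amide-type nitrogen.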